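This account rests on a few compounds, and the source may have more. Where it says the series, first, only, none or still open, it means among the compounds named here.

Compound 2 `Cc1cc(Cc2cccc(Br)c2)c(=O)n(CC(=O)Nc2ccc(Br)cc2)n1` is the point of departure. In an assay on HL-60 cells for agonist activity at N-formyl peptide receptor 3 (Homo sapiens), read by calcium flux (on this read-out lower numbers stand for an effect already at smaller amounts and higher numbers for an effect only at larger amounts of compound), compound 2 gives > 50000 nM, which is a limit of the assay and not a number. Going by the values given here, its one measured neighbour is compound 1 `Cc1cc(Cc2ccccc2)c(=O)n(CC(=O)Nc2ccc(Br)cc2)n1`. In this assay compound 1 gives > 50000 nM, again a limit. Among the compounds with values here, the only measured step, a step that the two limits leave unreadable from compound 1 to compound 2, therefore remains unreadable, and the whole of the evidence is the limit of > 50000 nM in this assay, at which 2 of the 2 values shown sit.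

Compound 3 `COc1cc(Cc2cc(C)nn(CC(=O)Nc3ccc(Br)cc3)c2=O)cc(OC)c1` differs from compound 2 by 3,5-dimethoxyphenyl in place of 3-bromophenyl on a saturated chain carbon bound to an aromatic carbon. Within the data shown here, no measured step bears on this change directly, since the one step that exists concerns a bromine on a different ring and is itself unreadable in size. With both measured values sitting at the limit, there is nothing that would point to a rise in potency, and the step of a number no higher from compound 2 to compound 3 (the limit leaves the size open) is expected to be none beyond the scatter. Compound 3 is accordingly estimated to stay at the limit as well, at 50000 nM with a range from 10000 nM to 200000 nM, most likely reported again only as a limit.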

Compound 3, half-maximal effective concentration: > 50000 nM
Compound 3 gave a limit, no number; the forecaster's own chance of this, stated with the estimate: 85%; the middle value lies on the limit itself.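

Compound 3 gives only a limit of the assay, as compound 1 and compound 2 do, so the steps joining compound 3 to compound 1 and to compound 2 cannot be read: the limit of > 50000 nM in this assay, at which 3 of the 3 values shown sit.

The compounds shown leave open whether any change on the shared core can give a measurable value in this assay, and how large any difference between these groups would be.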